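Replacing a Methylamino Group with a Chloroanilino Group

This account rests on a few compounds, and the source may have more. Where it says the series, first, only, none or still open, it means among the compounds named here.

Compound 1 `Cc1nnc(-c2nsc3ccccc23)o1` and compound 2 `CNc1nnc(-c2nsc3ccccc23)o1` share the same core and differ at a single aromatic carbon. In a functional assay on the whole organism for inhibition, with Rattus norvegicus as the target, with a stated time of 2 h, at a dose of 100 mg/kg by the intraperitoneal route (a higher number here means more inhibition at the dose given (going by the name of the read-out), a lower number less inhibition), compound 1 gives 69%, and in this assay compound 2 gives 67%. The step of a number 2 percentage points lower from compound 1 to compound 2 (within the scatter) tells that the two numbers lie within the scatter of this kind of measurement. Among the compounds with values here, compound 2 thus holds the lower of the two numbers known, yet it is not separated from compound 1 by more than the scatter.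

Compound 3 `Clc1ccc(Nc2nnc(-c3nsc4ccccc34)o2)cc1` remains to be measured. It differs from compound 2 by 4-chlorophenyl in place of methyl on a nitrogen on an aromatic ring. Within the data shown here, no measured pair shows what happens when a ring enters on that nitrogen; the only step recorded, a number 2 percentage points lower from compound 1 to compound 2 (within the scatter), concerns the arrival of the methylamino group itself and stayed within the scatter. The expectation for compound 3 therefore rests on the general level of compound 1 and compound 2 rather than on a comparable change, and a step of a number 7 percentage points lower from compound 2 to compound 3 (within the scatter) is expected, with no clear direction beyond the scatter. Compound 3 is estimated to give 60% in this assay, within 35% to 85%.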

Compound 3, a percentage reported as inhibition, in the whole organism at one dose (the size of the read-out at that dose, not a potency): 48%
For compound 3 the middle estimate is 12 percentage points above the measured one; measured number inside the range.
By their numbers in this assay, from the lowest: compound 3; then compounds 2 and 1 (each within the scatter of the next).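

Placing 4-chlorophenyl in place of methyl on a nitrogen on an aromatic ring gives a number 19 percentage points lower from compound 2 to compound 3 (beyond the scatter) in this assay, and this is the first step in the series to pass beyond the scatter. The earlier step, a number 2 percentage points lower from compound 1 to compound 2 (within the scatter), had left open whether this read-out responds to changes at this part of the molecule at all, whereas this pair shows that it does respond to what the nitrogen carries, with the larger, ring-bearing group on the lower side. The change does not abolish the effect, as compound 3 still gives 48% at the single dose tested, and nothing available bears on why the number falls.

The compounds shown do not tell whether the ring or the chlorine on it accounts for the step, and they do not show whether a plain phenyl or a longer chain such as propyl on the same nitrogen would stand with compound 2 or with compound 3. They also leave open how an amine or a carboxylic acid on that ring would read in this assay at this dose.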